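Taking the chloro group off compound 1

A few compounds are considered here, and "the series" means these few. Any claim that something is new, unique, unknown or untested is made for them only; others in the source may bear on it.

Going by the values given here, in a functional assay on cells (Homo sapiens) for inhibition, read by MTT assay, with a stated time of 72 h (a higher number here means a weaker inhibitor, a lower number a stronger inhibitor), compound 1 `CCOC(=O)Cn1ncc2c(Nc3ccc(NC(=O)CCl)cc3)ncnc21` gives 3.51 ug/mL, the only number among the three values shown. Compound 2 `CCOC(=O)Cn1ncc2c(Nc3ccc(NS(=O)(=O)c4ccc([N+](=O)[O-])cc4)cc3)ncnc21` has no chloro group and is reported only as a limit, > 64 ug/mL. Compound 3 `O=C(O)Cn1ncc2c(Nc3ccc(NS(=O)(=O)c4ccc([N+](=O)[O-])cc4)cc3)ncnc21` has none either and is also a limit, > 100 ug/mL. Compound 4 `CCOC(=O)Cn1ncc2c(Nc3ccc(NC(C)=O)cc3)ncnc21` differs from compound 1 by a single change, (hydrogen in place of chloro on a saturated chain carbon bound to a carbonyl carbon), which turns (chloromethyl)carbonyl into acetyl. Among the compounds with values here, the one measured step, a step that the two limits leave unreadable from compound 2 to compound 3, lies at another place in the molecule and gives no size for this change. Within the data shown here, no measured pair tests the change directly, so any expectation is weakly founded. Weaker inhibition in this assay is tentatively expected, on the thin ground of compound 2 with its limit of > 64 ug/mL. The expected move is a 4.3-fold higher number from compound 1 to compound 4 (0.63 log units; beyond the scatter), an estimate with wide uncertainty. For compound 4 the estimated value is 15 ug/mL, with an expected range from 4 ug/mL to 60 ug/mL.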

Compound 4, half-maximal inhibitory concentration: > 64 ug/mL
Compound 4: only a limit was reported; the forecaster's own chance of this, stated with the estimate: 30%; at least 4.2-fold (0.63 log units) between middle value and limit.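

Hydrogen in place of chloro on a saturated chain carbon bound to a carbonyl carbon gives an at least 18-fold higher number from compound 1 to compound 4 (1.26 log units; beyond the scatter) in this assay. The earlier compounds offered no measured pair at this place, so this is the first size shown for the change, and it lies beyond the scatter. That size remains only a bound, since compound 4 is reported solely as a limit: the limit of > 64 ug/mL in this assay, at which 2 of the 4 values shown sit.

From the compounds shown here alone, how far the number of compound 4 actually lies from that of compound 1 stays open. Also open, going by these compounds, is whether another group at this carbon, such as bromo or an amine, or a longer chain in place of chloromethyl, would keep a number close to that of compound 1 or fall to the limit as well.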